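Flipping one ring centre in an inactive diamide pair

The source may hold more compounds than are shown below. What is called first, only, known or untested is meant among the compounds shown, and "the series" means these compounds.

In a functional assay on HEK293 cells for antagonist activity at metabotropic glutamate receptor 5 (Homo sapiens), read by FLIPR and calcium flux (a lower number here means a stronger inhibitor, a higher number a weaker inhibitor), compound 1 `N#Cc1cccc(C(=O)N[C@@H]2CCC[C@H](NC(=O)c3ccccn3)C2)c1` reaches only the limit of > 10000 nM. Compound 2 `O=C(N[C@H]1CCC[C@H](NC(=O)c2ccccn2)C1)c1cccc(Cl)c1` likewise gives only the limit of > 10000 nM in this assay. Compound 2 therefore stands at the limit of > 10000 nM in this assay, at which 2 of the 2 values shown sit, with no number to place it. Compound 3 `O=C(N[C@@H]1CCC[C@H](NC(=O)c2ccccn2)C1)c1cccc(Cl)c1` differs from compound 2 in that (the two compounds have the same atoms and bonds and differ only in configuration as drawn: 1 of 2 stereo elements differ; a stereocentre at a saturated ring carbon is drawn S in compound 2 and R in compound 3). Among the compounds with values here, no measured step of this kind is available; the expected step is a number no higher from compound 2 to compound 3 (the limit leaves the size open), none beyond the scatter. Compound 3 is accordingly estimated at 10000 nM, with a range from 2000 nM to 30000 nM.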

Compound 3, half-maximal inhibitory concentration: 1510 nM
Compound 3: the middle estimate sits 6.6-fold (0.82 log units) above what was measured; the measured number lies below the stated range.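

In this assay, the configuration at this saturated ring carbon matters, with an at least 6.6-fold lower number from compound 2 to compound 3 (0.82 log units; beyond the scatter), and nothing else changes within that pair: the fact that compounds 2 and 3 differ only in the configuration as drawn

With that configuration held, the aromatic substituent also matters: chloro in place of cyano on an aromatic carbon gives an at least 6.6-fold lower number from compound 1 to compound 3 (0.82 log units; beyond the scatter). Both steps are open-ended, as compound 1 and compound 2 each stand at a limit of the assay.

The compounds shown leave open how the configuration at the other ring stereocentre bears on the number. They also leave open whether bromo or methoxy in place of chloro would raise or lower it.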